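Shifting the halogen on the amide aryl group

The source may report more compounds than this note shows. Statements on the series, on what has been measured and on what is new or still open speak of the compounds shown alone.

The series shares one core. Compound 1 `O=C(CSC(=S)N[C@H]1CCOC1=O)Nc1ccc(Cl)cc1` gives 50300 nM in a functional assay on MCF7 cells (Homo sapiens) for cytotoxicity, read by MTT assay, with a stated time of 72 h; a lower number here means a stronger inhibitor, a higher number a weaker inhibitor. Compound 2 `O=C(CSC(=S)N[C@H]1CCOC1=O)Nc1ccc(Br)cc1` gives 66500 nM in this assay. The step of a 1.3-fold higher number from compound 1 to compound 2 (0.12 log units; within the scatter) lies within the scatter. Compound 3 `Cc1cccc(NC(=O)CSC(=S)N[C@H]2CCOC2=O)c1C` reaches only a limit of the assay, > 128000 nM in this assay. Among the two numbers given, compound 2 stands at the higher end, with compound 1 its nearest neighbour and within the scatter of it; the third value shown is a limit (the limit of > 128000 nM in this assay, at which 1 of the 3 values shown sits).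

Compound 4 `O=C(CSC(=S)N[C@H]1CCOC1=O)Nc1cccc(Cl)c1` has not been measured in this assay. It differs from compound 2 by 3-chlorophenyl in place of 4-bromophenyl on an amide-type nitrogen. For the measured compounds named here, the only measured step that bears on it, from compound 1 to compound 2, exchanged chloro for bromo on an aromatic carbon and stayed within the scatter. Going by the values given here, no measured step changes where a halogen sits on the aryl group, so the direction of such a change is open. Compound 3 carries a different substitution pattern and sits at a limit. The expectation is therefore a step of a 1.1-fold lower number from compound 2 to compound 4 (0.04 log units; within the scatter) in this assay, none beyond the scatter. Compound 4 is estimated at 60000 nM, within 25000 nM to 125000 nM.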

Compound 4, half-maximal inhibitory concentration: 46600 nM
The estimate for compound 4 lay 1.3-fold (0.11 log units) above the measured number; low and high end bracket the measured number.
By their numbers in this assay, from the lowest: compounds 4, 1 and 2 (each within the scatter of the next). At a limit, above all of these: compound 3.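

For the compounds shown here, exchanging 4-chlorophenyl for 3-chlorophenyl on the amide-type nitrogen gives the first reading of where the halogen sits, and a 1.1-fold lower number from compound 1 to compound 4 (0.03 log units; within the scatter) in this assay shows no separation between these two placements of chloro. The combined exchange of 4-bromophenyl for 3-chlorophenyl, which changes both the halogen and its place, also stays unresolved, with a 1.4-fold lower number from compound 2 to compound 4 (0.15 log units; within the scatter). Together with the earlier chloro-to-bromo step, these results put the three halogenated aryl amides, compounds 1, 2 and 4, in one band, so neither the identity of the halogen nor the shift from 4-chlorophenyl to 3-chlorophenyl separates them here.

From the compounds shown here alone, compound 3 remains a limit of the assay and not a number, so it cannot be placed relative to this band: the limit of > 128000 nM in this assay, at which 1 of the 4 values shown sits. Still open is whether any aryl substituent outside these halogens, such as methoxy, nitro, trifluoromethyl, an amine or a carboxylic acid, moves the series out of this band, and whether a 2-chlorophenyl group or a second chlorine on the ring would do so.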